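Swapping the Side Chain in the Tail Flick Test

The source may hold more compounds than are shown below. What is called first, only, known or untested is meant among the compounds shown, and "the series" means these compounds.

Measured compounds:
compound 1 `CC[C@H](C)[C@H](NC(=O)CN(c1nc(Cl)nc2[nH]cnc12)C1CC1)C(=O)O` gives 6.71% in a functional assay on the whole organism (Tail, strain ICR) with Mus musculus as the target, in the tail flick test, with a stated time of 150 min, at a dose of 25 umol/kg by the oral route; a lower number here means a weaker effect, a higher number a stronger effect of the compound at the dose given
compound 2 `O=C(CN(c1nc(Cl)nc2[nH]cnc12)C1CC1)N[C@@H](CC(=O)OCc1ccccc1)C(=O)OCc1ccccc1` gives 6.68%
compound 3 `CC[C@H](C)[C@H](NC(=O)CN(c1nc(Cl)nc2[nH]cnc12)C1CC1)C(=O)OCc1ccccc1` gives 6.9%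

All three compounds share one core and differ only in the part hanging from the carbon bound to the amide-type nitrogen and the carbonyl carbon, or in the group on the oxygen of that carbonyl. Compound 1 sits between the other two, yet its gap to compound 2 is nil and a number 0.2 percentage points higher from compound 1 to compound 3 (within the scatter), so the three numbers cannot be told apart.

The unmeasured compound 4 `CSCC[C@H](NC(=O)CN(c1nc(Cl)nc2[nH]cnc12)C1CC1)C(=O)O` is made from compound 1 by the change (2-(methylsulfanyl)ethyl in place of sec-butyl on a saturated chain carbon bound to an amide-type nitrogen and a carbonyl carbon). Among the measured compounds shown here, one measured step touches the same place: a number 0.2 percentage points higher from compound 2 to compound 3 (within the scatter). The other, a number 0.2 percentage points higher from compound 1 to compound 3 (within the scatter), sits at a different place. For the measured compounds named here, both steps are flat, and neither the side chain nor the ester end has moved the read-out in this assay so far. The expectation for compound 4 is therefore no step beyond the scatter, a number 0 percentage points lower from compound 1 to compound 4 (within the scatter), and its estimated value is 6.7%, within a range from 0% to 17%.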

Compound 4, a percentage reported as activity, at one dose (the size of the read-out at that dose, not a potency): 4.14%
Estimate against measurement, compound 4: 2.6 percentage points above, within the range that was stated.
By their numbers in this assay, from the lowest: compounds 4, 2, 1 and 3 (each within the scatter of the next).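

In this assay, among the compounds shown here, the step of a number 2.6 percentage points lower from compound 1 to compound 4 (within the scatter) is the first at this place, the saturated chain carbon bound to an amide-type nitrogen and a carbonyl carbon, to be read with the free carboxylic acid kept at the end of the molecule; the earlier step at this place joined two benzyl esters. The entering 2-(methylsulfanyl)ethyl has the same count of heavy atoms as sec-butyl, but it brings in sulfur and one hydrogen-bond acceptor and has no defined stereocentre, and even so the step stays inside the scatter, so this exchange at this place has not given a change that can be told apart from repeat noise. Nothing available links this result to any measured property of either group.

The compounds shown leave open whether a side chain carrying an amine, a phenyl ring or a longer chain at this place would give a step beyond the scatter. With one dose and one stated time, they also leave open whether the same flat picture would hold under other conditions of the test.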